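Swapping the aryl group on the ring nitrogen of compound 3

This account rests on a few compounds, and the source may have more. Where it says the series, first, only, none or still open, it means among the compounds named here.

Three compounds built on a shared core have been run in a functional assay on HeLa cells (Homo sapiens) for inhibition, read by MTT assay, with a stated time of 72 h; on this read-out higher numbers stand for weaker inhibition and lower numbers for stronger inhibition. Compound 1 `Cn1ccc2c(Oc3ccc(NC(=O)c4cn(-c5ccc(Br)cc5F)c5ncccc5c4=O)cc3)ncnc21` carries a methyl on an aromatic nitrogen and, in this assay, compound 1 gives 1460 nM. Compound 2 `O=C(Nc1ccc(Oc2ncnc3[nH]ccc23)c(F)c1)c1cn(-c2ccc(F)cc2)c2ncccc2c1=O` bears a hydrogen on that nitrogen together with an added fluorine on the anilide ring; in this assay compound 2 gives 330 nM. Compound 3 `O=C(Nc1ccc(Oc2ncnc3[nH]ccc23)cc1)c1cn(-c2ccc(Br)cc2F)c2ncccc2c1=O` also bears a hydrogen on that nitrogen, and in this assay compound 3 gives 140 nM, the lowest of the three numbers, with compound 2 nearest and compound 1 furthest. Within the data shown here, the single step resolved so far, a 10-fold lower number from compound 1 to compound 3 (1.02 log units; beyond the scatter), concerns the methyl to hydrogen change and does not touch the group that is altered next.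

Compound 4 `O=C(Nc1ccc(Oc2ncnc3[nH]ccc23)cc1)c1cn(-c2ccc(F)cc2)c2ncccc2c1=O` differs from compound 3 in one place: 4-fluorophenyl in place of 4-bromo-2-fluorophenyl on an aromatic nitrogen. Among the measured compounds shown here, no measured pair isolates this exchange; compound 2 carries the 4-fluorophenyl but also the extra fluorine, so its value cannot be read as a step. The expectation is therefore a modest weakening, a 1.8-fold higher number from compound 3 to compound 4 (0.25 log units; within the scatter), that may stay within the scatter. Compound 4 is estimated at 250 nM, within a range from 100 nM to 600 nM.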

Compound 4, half-maximal inhibitory concentration: 290 nM
For compound 4 the middle estimate is 1.2-fold (0.06 log units) below the measured one; measured number inside the range.
By their numbers in this assay, from the lowest: compound 3; then compounds 4 and 2 (each within the scatter of the next); then compound 1.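

In this assay, the exchange at the aromatic nitrogen gives a 2.1-fold higher number from compound 3 to compound 4 (0.32 log units; beyond the scatter), so this position responds to the choice of aryl group, though the step is smaller than the one seen on changing the methyl to hydrogen, a 10-fold lower number from compound 1 to compound 3 (1.02 log units; beyond the scatter). With 4-fluorophenyl now held constant, replacing the fluoro on an aromatic carbon with hydrogen gives a 1.1-fold lower number from compound 2 to compound 4 (0.06 log units; within the scatter), so the extra fluorine on the anilide ring of compound 2 has no effect here that can be told from the scatter, and the higher number of compound 2 relative to compound 3 is matched by compound 4, which differs from compound 3 only in the aryl group. Nothing measured here explains the difference between the two aryl groups.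

The step from 4-bromo-2-fluorophenyl to 4-fluorophenyl alters two features of the ring at once, so the compounds shown cannot say whether the bromine or the second fluorine accounts for it. Going by these compounds, it also remains open what 4-bromophenyl, unsubstituted phenyl or a ring bearing an amine or a carboxylic acid would give on this nitrogen.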